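The compounds below may be only part of what the source reports. "The series", "measured", "known", "first", "only" and "open" are said of these compounds alone.

In a functional assay on DU-145 cells (Homo sapiens) for inhibition, read by trypan blue exclusion, with a stated time of 72 h (on this read-out higher numbers stand for weaker inhibition and lower numbers for stronger inhibition), compound 1 `Cn1c(=O)c(S(=O)(=O)c2ccccc2)cc2cnc(Nc3cnc4[nH]ccc4c3)nc21` gives 1000 nM and compound 2 `Cn1c(=O)c(S(=O)(=O)c2ccc(F)cc2F)cc2cnc(Nc3cnc4[nH]ccc4c3)nc21` gives 750 nM on the same scale. These two numbers lie within the scatter of each other, so compound 2 stands level with compound 1. Compound 3 `Cn1c(=O)c(S(=O)(=O)c2ccc(Cl)cc2)cc2cnc(Nc3cnc4[nH]ccc4c3)nc21` has 4-chlorophenyl in place of 2,4-difluorophenyl on a sulfonyl sulfur. For the measured compounds named here, the only measured change at that sulfur is a 1.3-fold lower number from compound 1 to compound 2 (0.12 log units; within the scatter) for 2,4-difluorophenyl in place of phenyl, a small step within the scatter. No step beyond the scatter is therefore expected in this assay for the new group, and the estimate amounts to a 1.1-fold higher number from compound 2 to compound 3 (0.03 log units; within the scatter) in size. For compound 3 the estimated value is 800 nM with an expected range from 300 nM to 2000 nM on repeat measurement.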

Compound 3, half-maximal inhibitory concentration: 5000 nM
Compound 3: middle estimate off by 6.3-fold (0.80 log units), on the low side; the measured number lies above the stated range.
By their numbers in this assay, from the lowest: compounds 2 and 1 (each within the scatter of the next); then compound 3.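

In this assay, the group on the sulfonyl sulfur can clearly shift the number: compound 1 and compound 2 stand level, yet 4-chlorophenyl gives a 6.7-fold higher number from compound 2 to compound 3 (0.82 log units; beyond the scatter) and a 5.0-fold higher number from compound 1 to compound 3 (0.70 log units; beyond the scatter). Chloro in place of hydrogen on an aromatic carbon therefore moves the number beyond the scatter, in the direction of weaker inhibition, which the 2,4-difluorophenyl group of compound 2 did not do. Nothing available explains this step. Still open, from the compounds shown here alone, is how the number would respond to a methoxy group or an amine on that ring, or to an ethyl chain replacing the ring on the sulfonyl sulfur.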